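The source may report more compounds than this note shows. Statements on the series, on what has been measured and on what is new or still open speak of the compounds shown alone.

Of the compounds shown here, three built on one shared core have been measured in an assay on isolated protein for inhibition of histone deacetylase 8 (Homo sapiens), with a stated time of 1 h; on this read-out higher numbers stand for weaker inhibition and lower numbers for stronger inhibition. Compound 1 `Cc1ccc(NC(=O)COc2ccc3cc(/C=C4/SC(=O)NC4=O)ccc3c2)cc1` gives 9000 nM, compound 2 `O=C(COc1ccc2cc(/C=C3/SC(=O)NC3=O)ccc2c1)Nc1cccc(F)n1` gives 7200 nM, and compound 3 `O=C(COc1ccc2cc(/C=C3/SC(=O)NC3=O)ccc2c1)Nc1ccccc1` gives 4500 nM. Compound 3 has the lowest of the three numbers, yet both others sit within the scatter of it: a 1.6-fold lower number from compound 2 to compound 3 (0.20 log units; within the scatter) and a 2.0-fold lower number from compound 1 to compound 3 (0.30 log units; within the scatter). Compound 4 `O=C(COc1ccc2cc(/C=C3/SC(=O)NC3=O)ccc2c1)Nc1ccc([N+](=O)[O-])cc1` has not yet been measured. It differs from compound 3 in one place: nitro in place of hydrogen on an aromatic carbon. The step that bears most directly on this is the earlier change on an aromatic carbon of that ring, a 2.0-fold lower number from compound 1 to compound 3 (0.30 log units; within the scatter), which stayed within the scatter; the exchanges of the whole ring on the amide-type nitrogen, a 1.3-fold lower number from compound 1 to compound 2 (0.10 log units; within the scatter) and a 1.6-fold lower number from compound 2 to compound 3 (0.20 log units; within the scatter), likewise moved nothing beyond it. Among the compounds with values here, no measured compound carries a nitro group, so the expectation for compound 4 is a step of no clear direction, no change at the digits printed from compound 3 to compound 4 (within the scatter), remaining within the scatter. Compound 4 is therefore estimated in this assay at 4500 nM, with a range from 1500 nM to 13000 nM.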

Compound 4, half-maximal inhibitory concentration: 4000 nM
For compound 4 the middle estimate is 1.1-fold (0.05 log units) above the measured one; the range from low to high includes it.
By their numbers in this assay, from the lowest: compounds 4, 3, 2 and 1 (each within the scatter of the next, the first and the last beyond it).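

In this assay, a nitro group on the aromatic carbon para to a large group leaves the number within the scatter (a 1.1-fold lower number from compound 3 to compound 4 (0.05 log units; within the scatter)), so this position accepts a group of three heavy atoms with no clear shift from hydrogen. Within the data shown here, exchanging the whole ring on the amide-type nitrogen also stays within the scatter (a 1.8-fold lower number from compound 2 to compound 4 (0.26 log units; within the scatter)), whereas nitro in place of methyl at this carbon goes beyond it, though only modestly (a 2.3-fold lower number from compound 1 to compound 4 (0.35 log units; beyond the scatter)), and this is the first step to do so. Nothing shown accounts for this gap between the methyl and nitro compounds.

On these data alone, it remains open whether an amine, a carboxylic acid or a methoxy group at this carbon would move the number further. Also open, as far as these compounds go, is how a nitro group on another carbon of the ring would compare.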